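A few compounds are considered here, and "the series" means these few. Any claim that something is new, unique, unknown or untested is made for them only; others in the source may bear on it.

Compound 1 `CC#CC(CC(=O)O)c1ccc(OCc2ccn3cc(-c4ccc(C(C)C)cc4)nc3c2)cc1` gives 615 nM in an assay on isolated protein for agonist activity at Free fatty acid receptor 1 (Homo sapiens); a higher number here means that more compound is needed for the effect, a lower number that less compound is needed.
Compound 2 `CC#CC(CC(=O)O)c1ccc(OCc2ccc3nc(-c4ccccc4)cn3c2)cc1` gives 979 nM in this assay.
Compound 3 `CC#CC(CC(=O)O)c1ccc(OCc2ccc3nc(-c4ccc(F)cc4F)cn3c2)cc1` gives 825 nM in this assay.

Among these three, compound 1 shows the lowest number in this assay, yet its gaps to compound 3 and to compound 2 both fall within the scatter, so no order can be drawn from them. Compound 4 `CC#CC(CC(=O)O)c1ccc(OCc2ccn3cc(-c4cc(F)ccc4F)nc3c2)cc1` differs from compound 1 in one place: 2,5-difluorophenyl in place of 4-isopropylphenyl on an aromatic carbon. Within the data shown here, only one measured step bears on this change, and only in part: a 1.2-fold lower number from compound 2 to compound 3 (0.07 log units; within the scatter), a 2,4-difluorophenyl in place of phenyl on a different core. Among the measured compounds shown here, no measured pair shows the loss of the isopropyl group. The estimated value for compound 4 in this assay is 900 nM, with a range from 350 nM to 2500 nM. That estimate means an expected step of a 1.5-fold higher number from compound 1 to compound 4 (0.17 log units; within the scatter), close to the scatter.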

Compound 4, half-maximal effective concentration: 639 nM
The estimate for compound 4 lay 1.4-fold (0.15 log units) above the measured number, and the stated range covers the measured number.
By their numbers in this assay, from the lowest: compounds 1, 4, 3 and 2 (each within the scatter of the next).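

Swapping 4-isopropylphenyl for 2,5-difluorophenyl at this aromatic carbon of the five-membered ring gives a 1.0-fold higher number from compound 1 to compound 4 (0.02 log units; within the scatter) in this assay. Among these compounds, this is the first pair on a single core, and it shows that the isopropyl-bearing ring can give way to this difluorinated ring without a step beyond the scatter. Nothing available explains this result.

Still open, from the compounds shown here alone, is whether a morpholine, a pyridine or a plain phenyl at this carbon of the core of compound 1 would also stay within the scatter of compound 1.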